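Benzylamino nucleosides and cell growth: working notes

The source may report more compounds than this note shows. Statements on the series, on what has been measured and on what is new or still open speak of the compounds shown alone.

Measured so far in a functional assay on HOS cells (Homo sapiens) for antiproliferative activity, with a stated time of 72 h; a higher number here means a weaker inhibitor, a lower number a stronger inhibitor:
compound 1 `COc1ccccc1CNc1ncnc2c1ncn2[C@@H]1O[C@H](CO)[C@@H](O)[C@H]1O` — > 166000 nM
compound 2 `COc1ccc(CNc2ncnc3c2ncn3C2OC(CO)[C@@H](O)[C@H]2O)c(O)c1` — > 166000 nM

In this assay compound 1 gives > 166000 nM, which is a limit of the assay and not a number. Compound 2 gives > 166000 nM in this assay, again a limit. Among the measured compounds shown here, compound 1 thus stands at the limit, and the one further value shown sits there as well, so the two compounds cannot be ordered against each other; neither shows a measurable half-maximal inhibitory concentration within the range tested.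

Compound 3 `OC[C@H]1O[C@@H](n2cnc3c(NCc4cc(O)cc(O)c4)ncnc32)[C@H](O)[C@@H]1O` is still to be measured in this assay. Against compound 1 the change is 3,5-dihydroxyphenyl in place of 2-methoxyphenyl on a saturated chain carbon bound to a nitrogen on an aromatic ring. For the measured compounds named here, no step between measured compounds that differ in one place is available, so the size of this change has no direct counterpart in the data. The step that the limit leaves unreadable from compound 1 to compound 3 is expected to be none beyond the usual scatter because the limit of > 166000 nM in this assay, at which 2 of the 2 values shown sit, leaves no room to read a trend from either substituent. Compound 3 is estimated at 200000 nM, with a range from 50000 nM to 800000 nM, and most probably will again be reported only as a limit.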

Compound 3, half-maximal inhibitory concentration: > 166000 nM
Compound 3: no number, only a limit; the forecaster's own chance of this, stated with the estimate: 85%; the middle value is on the limit's open side.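

In this assay compound 3 gives > 166000 nM as a limit of the assay and not a number. No new step can be read between compound 1 and compound 3 because all the values stop at the same limit: the limit of > 166000 nM in this assay, at which 3 of the 3 values shown sit. The compounds shown leave open whether any benzylamino substituent on the shared core gives a measurable half-maximal inhibitory concentration in this assay within the range tested.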